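This account rests on a few compounds, and the source may have more. Where it says the series, first, only, none or still open, it means among the compounds named here.

Compound 3, `O=C(O)c1ccccc1OCc1ccc(OCc2c(-c3c(Cl)cccc3Cl)noc2C2CC2)nc1C(F)(F)F`, is the weakest of the three measured compounds in an assay on isolated protein for agonist activity at Bile acid receptor (Homo sapiens), read by FRET (a higher number here means a larger maximal response, a lower number a smaller maximal response), where compound 3 gives 91%. Its neighbours are compound 1, `Cc1cc(OCc2c(-c3c(Cl)cccc3Cl)noc2C(C)C)ncc1[N+](=O)[O-]`, for which compound 1 gives 101% in this assay, a number that lies within the scatter of compound 3, and compound 2, `CN(Cc1cccc(C(=O)O)c1)c1ccc(OCc2c(-c3c(Cl)cccc3Cl)noc2C2CC2)nc1C(F)(F)F`, for which compound 2 gives 102%. For the measured compounds named here, the one single-point change measured so far is a number 11 percentage points lower from compound 2 to compound 3 (beyond the scatter), a modest loss that still exceeds the scatter.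

Compound 4, `O=C(O)c1ccc(OCc2ccc(OCc3c(-c4c(Cl)cccc4Cl)noc3C3CC3)nc2C(F)(F)F)cc1`, keeps every atom of compound 3 and only rearranges the carboxylic acid-bearing arm: 4-carboxyphenyl in place of 2-carboxyphenyl on an oxygen on a saturated carbon. Said another way, 2-carboxyphenoxy becomes 4-carboxyphenoxy.

Going by the values given here, no measured step isolates this kind of change. The step from compound 2 to compound 3 swapped the whole arm, including its linker, so it bears on compound 4 only loosely; it shows that altering this arm shifts the maximal response by roughly one scatter width at most. A step of similar or smaller size is therefore expected here, with no clear direction, and compound 4 is estimated to show a number 6 percentage points higher from compound 3 to compound 4 (within the scatter), landing at 97% in this assay, plausibly anywhere from 85% to 110%.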

Compound 4, largest response reached (reported as efficacy), in percent of the reference or control that the assay uses: 86%
For compound 4 the middle estimate is 11 percentage points above the measured one, within the range that was stated.
By their numbers in this assay, from the lowest: compounds 4, 3, 1 and 2 (each within the scatter of the next, the first and the last beyond it).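

Changing 2-carboxyphenoxy to 4-carboxyphenoxy gives a step that stays inside the usual scatter (a number 5 percentage points lower from compound 3 to compound 4 (within the scatter)), so in this assay these two placements of the carboxylic acid on the phenyl ring cannot be told apart. The larger shift appears only when the whole arm is exchanged: replacing (3-carboxybenzyl)(methyl)amino with (4-carboxyphenoxy)methyl gives a modest step beyond the scatter (a number 16 percentage points lower from compound 2 to compound 4 (beyond the scatter)), and the exchange for (2-carboxyphenoxy)methyl points the same way (a number 11 percentage points lower from compound 2 to compound 3 (beyond the scatter)). Among these compounds, then, the maximal response follows the change of the whole arm more closely than the placement of the acid on the ring, and no supporting data are available to explain either step.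

What the compounds shown leave open is whether the arm needs its carboxylic acid at all, since an amide or a nitrile in that place could give a different maximal response. Also open, as far as these compounds go, is how a longer chain between the oxygen and the phenyl ring would behave in this assay.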